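Sulfonyl-aryl swap on the quinoline series: clearance notes

The source may report more compounds than this note shows. Statements on the series, on what has been measured and on what is new or still open speak of the compounds shown alone.

Measured compounds in an ADME assay on microsomes from liver (Homo sapiens) for metabolic stability, tested at 2.5 uM; a higher number here means faster removal of the compound, a lower number slower removal:
compound 1 `Cc1ccc(S(=O)(=O)c2cnc3cc(F)ccc3c2-c2ccc(F)cc2)cc1C`: 9.25 mL/min
compound 2 `COc1cccc(-c2c(S(=O)(=O)c3ccc(C)c(C)c3)cnc3cc(F)ccc23)c1`: 8.78 mL/min
compound 3 `Cc1ccc(S(=O)(=O)c2cnc3cc(F)ccc3c2-c2cccc(Cl)c2)cc1C`: 4.01 mL/min

Compound 2 holds the second highest of the three numbers. Its nearest neighbour is compound 1, with a 1.1-fold lower number from compound 1 to compound 2 (0.02 log units; within the scatter), a gap that lies within the scatter. The furthest is compound 3, with a 2.2-fold lower number from compound 2 to compound 3 (0.34 log units; beyond the scatter), a modest step beyond the scatter. The step of a 2.3-fold lower number from compound 1 to compound 3 (0.36 log units; beyond the scatter) is of similar size.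

The next compound is compound 4 `COc1cccc(-c2c(S(=O)(=O)c3ccc(F)c(F)c3)cnc3cc(F)ccc23)c1`. The change from compound 2 is 3,4-difluorophenyl in place of 3,4-dimethylphenyl on a sulfonyl sulfur.

Among the measured compounds shown here, none of the measured steps bears on this change: all three alter the aryl on the aromatic carbon of the shared core, while the 3,4-dimethylphenyl on the sulfonyl sulfur is the same in compounds 1, 2 and 3. For the measured compounds named here, with no comparable step in hand, no step beyond the scatter is expected in this assay in either direction. Compound 4 is therefore expected to give about 8.5 mL/min in this assay, within 4 mL/min to 18 mL/min. The expected step is a 1.0-fold lower number from compound 2 to compound 4 (0.01 log units; within the scatter).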

Compound 4, intrinsic clearance in a liver preparation (reported as CLH), per the amount of preparation that the assay uses: 1.77 mL/min
Compound 4: middle estimate off by 4.8-fold (0.68 log units), on the high side; the whole stated range lies above it.
By their numbers in this assay, from the lowest: compound 4; then compound 3; then compounds 2 and 1 (each within the scatter of the next).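

The aryl on the sulfonyl sulfur is not a silent position in this assay: 3,4-difluorophenyl in place of 3,4-dimethylphenyl gives a 5.0-fold lower number from compound 2 to compound 4 (0.70 log units; beyond the scatter), a larger step than any seen so far on changing the aryl on the aromatic carbon of the shared core. The two groups have the same heavy-atom count and the same ring, so the step attaches to the exchange of the methyl groups for fluorines alone. No measurement shown here bears on why this exchange lowers the number.

Open, as far as these compounds go, is whether the step belongs to one fluorine or to both, and whether it holds with 3-chlorophenyl or 4-fluorophenyl on the aromatic carbon. Also open, from the compounds shown here alone, is how an amine or a carboxylic acid on the sulfonyl aryl would read in this assay.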